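The source may hold more compounds than are shown below. What is called first, only, known or untested is meant among the compounds shown, and "the series" means these compounds.

Three compounds share one core and differ only in the group carried on the amide-type nitrogen in the ring. Compound 1 `O=C(O)c1cc(-c2cccc(COc3ccc4c(c3)CN(C3CCCCC3)C4=O)c2)ccc1Cl` carries a cyclohexyl there and, in an ADME assay on a cell-free system (plasma, Rattus norvegicus), with a stated time of 60 min (a higher number here means that more of the compound is left, a lower number that less of the compound is left), compound 1 gives 99%. Compound 2 `O=C(O)c1cc(-c2cccc(COc3ccc4c(c3)CN(c3ccccc3)C4=O)c2)ccc1Cl` carries a phenyl, and in this assay compound 2 gives 100%. Compound 3 `CCCN1Cc2cc(OCc3cccc(-c4ccc(Cl)c(C(=O)O)c4)c3)ccc2C1=O` carries a propyl, and in this assay compound 3 gives 100%, level with compound 2 at the digits shown and together with it the highest of the three numbers. The swaps among them moved almost nothing: a number 1 percentage points higher from compound 1 to compound 2 (within the scatter), a number 1 percentage points higher from compound 1 to compound 3 (within the scatter), and no change at the digits printed from compound 2 to compound 3 (within the scatter).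

Compound 4 `CC(C)CCN1Cc2cc(OCc3cccc(-c4ccc(Cl)c(C(=O)O)c4)c3)ccc2C1=O` is reached from compound 3 by the change (isopropyl in place of methyl on a saturated chain carbon, two bonds along the chain from an amide-type nitrogen in a ring). For the measured compounds named here, no measured step alters a chain carbon in this way; the three steps above all exchange the whole group on the nitrogen, and each stayed within the scatter. Compound 4 is therefore expected to sit near the ceiling, with a number 1 percentage points lower from compound 3 to compound 4 (within the scatter) in this assay, and its estimated value is 99%, within 92% to 100%.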

Compound 4, percent of the compound remaining: 94%
The estimate for compound 4 lay 5 percentage points above the measured number, and the stated range covers the measured number.
By their numbers in this assay, from the lowest: compounds 4, 1, 2 and 3 (each within the scatter of the next).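

In this assay, the first change made along the chain rather than to the whole group, isopropyl in place of methyl on a saturated chain carbon, two bonds along the chain from an amide-type nitrogen in a ring, gives a number 6 percentage points lower from compound 3 to compound 4 (within the scatter). Read as swaps of the whole group on that nitrogen, isopentyl in place of phenyl gives a number 6 percentage points lower from compound 2 to compound 4 (within the scatter), and isopentyl in place of cyclohexyl gives a number 5 percentage points lower from compound 1 to compound 4 (within the scatter), so a branched chain end joins the other three groups in a set this read-out cannot separate. Nothing available bears on why these numbers fall as they do.

All four compounds keep the carboxylic acid and the shared core. Open, as far as these compounds go, is whether an amine or a hydroxyl on the chain, or a much longer chain, would also stay within the scatter.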